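The source may hold more compounds than are shown below. What is called first, only, known or untested is meant among the compounds shown, and "the series" means these compounds.

In a functional assay on MDA-MB-231 cells (Homo sapiens) for antiproliferative activity, read by MTT assay, with a stated time of 48 h (on this read-out higher numbers stand for weaker inhibition and lower numbers for stronger inhibition), compound 1 `CN1C(=O)C(O)(Cc2nnn[nH]2)c2ccccc21` is recorded at > 100000 nM as a limit and not a number. Compound 2 `CCN1C(=O)C(O)(Cc2nnn[nH]2)c2ccccc21` is recorded at > 100000 nM as a limit of the assay. Compound 3 `O=C1N(Cc2ccc(Br)cc2)c2ccc(Cl)cc2C1(O)Cc1nnn[nH]1` is likewise recorded at > 100000 nM as a limit. Compound 1 thus stands at the limit of > 100000 nM in this assay, at which 3 of the 3 values shown sit, and no number places it more closely.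

Compound 4 `CN1C(=O)C(O)(Cc2nnn[nH]2)c2cc(Br)ccc21` differs from compound 1 by a single change, bromo in place of hydrogen on an aromatic carbon in words bromo in place of hydrogen on an aromatic carbon. Within the data shown here, the one measured step, a step that the two limits leave unreadable from compound 1 to compound 2 concerns a different place, a saturated chain carbon bound to an amide-type nitrogen in a ring, and gives no size to carry over. Among the measured compounds shown here, no measured step touches the aromatic carbon. With nothing readable to go on, no step beyond the scatter is expected in this assay and any departure could only show as stronger inhibition. The step of a number no higher from compound 1 to compound 4 (the limit leaves the size open) is therefore expected to be unreadable or small. For compound 4 the estimated value is 100000 nM with an expected range from 40000 nM to 200000 nM and a report at the limit is the likeliest outcome.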

Compound 4, half-maximal inhibitory concentration: 67300 nM
Compound 4: the middle estimate sits 1.5-fold (0.17 log units) above what was measured; the range from low to high includes it.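

In this assay, bromo in place of hydrogen on an aromatic carbon, meta to a fused ring and para to a fused ring, gives an at least 1.4-fold lower number from compound 1 to compound 4 (0.17 log units; that floor lies within the scatter). On these data alone, compound 1 stands only at a limit, so the true size of this step stays open: the printed floor does not go beyond the scatter, and the change may do little or considerably more. What this position adds is a readable result, for compound 4 gives 67300 nM, a number in the assay's range. Compound 1, compound 2 and compound 3 each stay at a limit and not a number: the limit of > 100000 nM in this assay, at which 3 of the 4 values shown sit.

The compounds shown leave open whether a different group on this same aromatic carbon, such as methoxy, an amine or a carboxylic acid, would give a lower number than bromo, and whether bromo would give the same result on the other carbons of that ring. They also leave open how bromo at this position behaves when the methyl on the amide-type nitrogen gives way to a longer chain such as propyl or butyl, or when the tetrazole-bearing side chain is replaced by a carboxylic acid.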